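This account rests on a few compounds, and the source may have more. Where it says the series, first, only, none or still open, it means among the compounds named here.

The measured compounds:
Compound 1 `COC(=O)c1ccc2ccc(C(=O)N(C)C)c-2cc1`, which in a physicochemical assay for lipophilicity (a lower number here means a more polar compound, a higher number a more lipophilic compound), gives 2.1.
Compound 2 `CN(C)C(=O)c1ccc2cccccc1-2`, which in this assay gives 1.6.
Compound 3 `CN(C)C(=O)c1cn(C)c2ccccc12`, which in this assay gives 1.3.

Compound 1 differs from compound 2 by one change, (methoxycarbonyl in place of hydrogen on an aromatic carbon), and this change made a step of a number 0.50 log units higher from compound 2 to compound 1 (beyond the scatter). Compound 4 `COC(=O)c1ccc2c(C(=O)N(C)C)cn(C)c2c1`, not yet measured, differs from compound 3 by methoxycarbonyl in place of hydrogen on an aromatic carbon. The difference between the cores of compound 2 and compound 3 is not broken down here. The place is not the same: in compound 1 the group sits on a seven-membered aromatic ring of carbon only, in compound 4 on a six-membered aromatic ring of carbon only, meta to a fused ring and para to a fused ring, so this is the same kind of change, not the same. The step from compound 3 is expected to be a number 0.50 log units higher from compound 3 to compound 4 (beyond the scatter), resting on the step seen in compound 2 to compound 1, a number 0.50 log units higher from compound 2 to compound 1 (beyond the scatter). Compound 4 is therefore estimated at 1.8 in this assay.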

Compound 4, partition coefficient: 1.4
Beside the measured number, compound 4's estimate is 0.40 log units above it; the measured number lies below the stated range.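

The same change gave a number 0.10 log units higher from compound 3 to compound 4 (within the scatter) in this assay, against a number 0.50 log units higher from compound 2 to compound 1 (beyond the scatter) on the other core, so the step seen on one core did not carry over in size to the other. With a single pair on each core and the group at a different place in each, this does not show whether core or place governs the size of the step, nor how the change would behave on any further core. Nothing given here bears on the reason for the difference.

The compounds shown leave open how methoxycarbonyl would read at another place on the core of compound 3. They also leave open whether a carboxylic acid or an amine in its stead would give similar steps on the two cores.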